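The compounds below may be only part of what the source reports. "The series", "measured", "known", "first", "only" and "open" are said of these compounds alone.

Measured in a functional assay on HCT-116 cells (Homo sapiens) for antiproliferative activity, read by MTT assay, with a stated time of 72 h; on this read-out lower numbers stand for stronger inhibition and higher numbers for weaker inhibition:

- Compound 1 `CC(C)(C)NC(=O)CCc1cccc2c1B(O)OC2`: > 100000 nM (a limit of the assay, not a number)
- Compound 2 `O=C(CCc1cccc2c1B(O)OC2)Nc1ccc(Br)cc1`: 46000 nM
- Compound 3 `O=C(CCc1cccc2c1B(O)OC2)Nc1cccc(Br)c1`: 1400 nM

Compound 3 has the lowest number of the set at 1400 nM and is the most potent of the three. Its nearest neighbour is compound 2 at 46000 nM. Compound 1 has only a limit, so it gives no exact comparison.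

Compound 4 `CC(C)c1cccc(NC(=O)CCc2cccc3c2B(O)OC3)c1` keeps the rest of compound 3 and changes one group: isopropyl in place of bromo on an aromatic carbon. Going by the values given here, no measured step makes this exchange, so the evidence is indirect. Swapping the tert-butyl for a bromophenyl group gave an at least 2.1-fold lower number from compound 1 to compound 2 (0.33 log units; beyond the scatter) and an at least 71-fold lower number from compound 1 to compound 3 (1.85 log units; beyond the scatter). Shifting the bromo on that ring gave a 33-fold lower number from compound 2 to compound 3 (1.52 log units; beyond the scatter), which shows that the placement of a group on this ring can matter greatly. Compound 4 carries its new group where compound 3 carries the bromo, so it is expected to stay close to compound 3 rather than fall back towards compound 2. No step beyond the scatter is expected, and the expected change is a 1.4-fold higher number from compound 3 to compound 4 (0.15 log units; within the scatter). Compound 4 is estimated at 2000 nM, with an expected range from 500 nM to 9000 nM.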

Compound 4, half-maximal inhibitory concentration: 1600 nM
Beside the measured number, compound 4's estimate is 1.3-fold (0.10 log units) above it, within the range that was stated.
By their numbers in this assay, from the lowest: compounds 3 and 4 (each within the scatter of the next); then compound 2. At a limit, above all of these: compound 1.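

In this assay, isopropyl in place of bromo gave a 1.1-fold higher number from compound 3 to compound 4 (0.06 log units; within the scatter). The earlier compounds shown here showed only that moving the bromo on this ring, or replacing the tert-butyl with a bromophenyl group, changes the number. Compound 4 adds something new: at this place on the ring, meta to a large group, the bromine is not needed, and an isopropyl group with three carbon atoms in place of that single atom leaves the number within the scatter. Nothing in the data shown explains why these two groups match here.

Going by these compounds, both groups carry no hydrogen-bond donors or acceptors, so it remains open whether an amine, a hydroxyl or a carboxylic acid at this place would give a similar number, or whether a longer chain such as butyl would still fit the same pattern. On these data alone, it also remains open whether isopropyl in the 4-bromophenyl position of compound 2 would give a number as high as that compound's, as the bromo comparison alone cannot say whether the placement effect extends to other groups.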